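Lengthening the Basic Side Chain of Compound 1

The source may report more compounds than this note shows. Statements on the series, on what has been measured and on what is new or still open speak of the compounds shown alone.

Compound 1 `N#Cc1nc2c(-c3nc4ccccc4[nH]3)c(N)n(CCN3CCCC3)c2nc1C#N` carries a pyrrolidin-1-yl group on a saturated chain carbon, two bonds along the chain from an aromatic nitrogen. In a functional assay on Raji cells (Homo sapiens) for antiproliferative activity, read by MTT assay, with a stated time of 48 h (on this read-out higher numbers stand for weaker inhibition and lower numbers for stronger inhibition), compound 1 gives only a limit, > 50000 nM. It stands at the limit of > 50000 nM in this assay, at which 2 of the 3 values shown sit, so no number places it. Compound 3 `N#Cc1nc2c(-c3nc4ccccc4[nH]3)c(N)n(CCCO)c2nc1C#N` likewise gives only a limit in this assay, > 50000 nM. Among the compounds with values here, compound 2 `CCN(CC)CCCn1c(N)c(-c2nc3ccccc3[nH]2)c2nc(C#N)c(C#N)nc21` is the one member of the set with a measured number, 1870 nM in this assay. The step of an at least 26-fold lower number from compound 1 to compound 2 (1.42 log units; beyond the scatter) shows what a tertiary amine carried one bond further out does here, and the step of an at least 26-fold higher number from compound 2 to compound 3 (1.42 log units; beyond the scatter) shows what replacing that amine with a hydroxy group does, while the step that the two limits leave unreadable from compound 1 to compound 3 cannot be sized. Compound 4 `N#Cc1nc2c(-c3nc4ccccc4[nH]3)c(N)n(CCCN3CCCCC3)c2nc1C#N` differs from compound 1 by (piperidin-1-yl)methyl in place of pyrrolidin-1-yl on a saturated chain carbon, two bonds along the chain from an aromatic nitrogen. Within the data shown here, the change resembles the one from compound 1 to compound 2: a cyclic tertiary amine is kept, the chain is longer, and the ring is larger. The step from compound 1 to compound 2 is the one that bears on it, and a step of similar direction and size is expected, an at least 20-fold lower number from compound 1 to compound 4 (1.30 log units; beyond the scatter). Compound 4 is therefore expected to give 2500 nM in this assay, within 500 nM to 15000 nM.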

Compound 4, half-maximal inhibitory concentration: 3380 nM
Beside the measured number, compound 4's estimate is 1.4-fold (0.13 log units) below it, within the range that was stated.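

In this assay, the change to a 3-(piperidin-1-yl)propyl chain gives an at least 14-fold lower number from compound 1 to compound 4 (1.17 log units; beyond the scatter), so a second compound with a tertiary amine at the end of this longer chain reads well clear of the limit, and the effect no longer rests on compound 2 alone. Set against the hydroxy group at the same place, piperidin-1-yl gives an at least 14-fold lower number from compound 3 to compound 4 (1.17 log units; beyond the scatter), which shows that the difference seen earlier with diethylamino also holds for a cyclic amine. The new information is that the form of the amine makes no readable difference here: the step is a 1.8-fold higher number from compound 2 to compound 4 (0.26 log units; within the scatter), so an open diethylamino group and a piperidin-1-yl ring cannot be told apart in this assay.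

Chain length and ring size change together from compound 1 to compound 4, so their separate shares stay open, and a 3-(pyrrolidin-1-yl)propyl chain or a longer chain carrying the same amines would bear on this. The steps from compounds 1 and 3 are also only bounds, since each of these compounds gives a limit and not a number: the limit of > 50000 nM in this assay, at which 2 of the 4 values shown sit.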